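From 4-propylphenyl to cyclohexyl on the amine nitrogen

The source may report more compounds than this note shows. Statements on the series, on what has been measured and on what is new or still open speak of the compounds shown alone.

In a functional assay on HeLa cells (Homo sapiens) for inhibition, read by sulforhodamine B assay (on this read-out lower numbers stand for stronger inhibition and higher numbers for weaker inhibition), compound 1 (`CCCc1ccc(NC2=CC(=O)c3nc4n(c3C2=O)[C@H]2OC[C@@H](O)[C@H]2OC4)cc1`) gives 4990 nM. Compound 3 (`Cc1ccc(NC2=CC(=O)c3c(nc4n3[C@H]3OC[C@@H](O)[C@H]3OC4)C2=O)cc1C`) gives 4320 nM, which lies within the scatter of the value for compound 1. Compound 2 (`O=C1C(Nc2ccccc2)=CC(=O)c2c1nc1n2[C@H]2OC[C@@H](O)[C@H]2OC1`) is reported as > 8000 nM, which is a limit and not a number. Compound 1 therefore stands level with compound 3 on the numbers shown.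

Compound 4 (`O=C1C=C(NC2CCCCC2)C(=O)c2c1nc1n2[C@H]2OC[C@@H](O)[C@H]2OC1`) differs from compound 1 on the amine nitrogen: cyclohexyl in place of 4-propylphenyl on an amine nitrogen. Within the data shown here, only one measured step concerns a group at this place, an at least 1.8-fold lower number from compound 2 to compound 3 (0.26 log units; that floor lies within the scatter). Among the measured compounds shown here, that step exchanges one aromatic group for another, and no measured step shows what a non-aromatic ring does here. No step beyond the scatter is therefore expected in this assay, with only a slight lean towards weaker inhibition. The estimated step is a 1.2-fold higher number from compound 1 to compound 4 (0.08 log units; within the scatter). Compound 4 is estimated at 6000 nM, with an expected range from 2500 nM to 15000 nM.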

Compound 4, half-maximal inhibitory concentration: > 16000 nM
Compound 4 ended at the assay's limit; the forecaster's own chance of this, stated with the estimate: 35%; middle value at least 2.6-fold (0.42 log units) away from the limit.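

In this assay, cyclohexyl in place of 4-propylphenyl on the amine nitrogen gives an at least 3.2-fold higher number from compound 1 to compound 4 (0.50 log units; beyond the scatter). Among these compounds, this is the first step at this place that lies beyond the scatter, since the earlier step, between two aromatic groups, had a floor within it, so this position does not accept every six-membered carbon ring equally. The reading for compound 4 is a limit and not a number, so the step gives only a floor: the limit of > 16000 nM in this assay, at which 1 of the 4 values shown sits.

The change removes the aromatic ring and the propyl chain together, so their shares cannot be separated, and no step can be read between compound 2, itself a limit, and compound 4. Going by these compounds, how a 4-propylcyclohexyl group, an open hexyl chain or a phenyl ring bearing an amine would read on this nitrogen stays open.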